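Shifting the Methoxy Groups on One Aromatic Ring

A few compounds are considered here, and "the series" means these few. Any claim that something is new, unique, unknown or untested is made for them only; others in the source may bear on it.

Going by the values given here, in an ADME assay on ECV-304 cells (Homo sapiens) for cytotoxicity, read by MTT assay, with a stated time of 72 h (a higher number here means a weaker inhibitor, a lower number a stronger inhibitor), compound 2 `COc1ccc(OC)c(C2=C(c3cc(OC)c(OC)c(OC)c3)C(=O)CC2O[SiH2]C(C)(C)C)c1` gives 6.5 ug/mL, the lowest number among the compounds measured so far. Compound 3 `COc1ccc(C2=C(c3cc(OC)c(OC)c(OC)c3)C(=O)C(O)C2)cc1Cl`, built differently, gives a higher number, 20 ug/mL. Compound 1 `COc1ccc(C2=C(c3cc(OC)c(OC)c(OC)c3)C(=O)CC2O[SiH2]C(C)(C)C)cc1` returns only a limit, > 100 ug/mL.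

Compound 4 `COc1ccc(C2=C(c3cc(OC)c(OC)c(OC)c3)C(=O)CC2O[SiH2]C(C)(C)C)cc1OC` has not yet been measured. It contains the same atoms as compound 2, joined differently: 3,4-dimethoxyphenyl in place of 2,5-dimethoxyphenyl on a double-bonded ring carbon. In words, 3,4-dimethoxyphenyl takes the place of 2,5-dimethoxyphenyl on a double-bonded ring carbon.

Among the compounds with values here, only one measured step bears on this change: an at least 15-fold lower number from compound 1 to compound 2 (1.18 log units; beyond the scatter), a large step that came with 2,5-dimethoxyphenyl replacing 4-methoxyphenyl. Compound 4 gives up that 2,5-dimethoxyphenyl, while the name of its new group still contains the 4-methoxy of compound 1, so part of this large step may well be lost. The expected outcome is a 4.6-fold higher number from compound 2 to compound 4 (0.66 log units; beyond the scatter), a move towards weaker inhibition, though a single step makes this a loose expectation. For compound 4 the estimated value is 30 ug/mL, with an expected range from 7 ug/mL to 130 ug/mL.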

Compound 4, half-maximal inhibitory concentration: > 100 ug/mL
Compound 4 gave a limit, no number; the forecaster's own chance of this, stated with the estimate: 25%; middle value at least 3.3-fold (0.52 log units) from the limit.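

In this assay, compounds 2 and 4 have the same atoms and differ only in how the two methoxy groups are arranged on this ring, yet the result is an at least 15-fold higher number from compound 2 to compound 4 (1.18 log units; beyond the scatter). A second methoxy group on this ring therefore does not by itself give the low number, as the 2,5-dimethoxyphenyl does and the 3,4-dimethoxyphenyl does not. The step that adds a methoxy group to compound 1 to give compound 4 cannot be read, and the value of compound 4 is itself a limit of the assay: the limit of > 100 ug/mL in this assay, at which 2 of the 4 values shown sit.

Still open, from the compounds shown here alone, is whether both methoxy groups of the 2,5-dimethoxyphenyl are needed for the low number of compound 2, or only one of them. Also open, going by these compounds, is whether an amine or an ethoxy group in place of either one would keep that number.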